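A few compounds are considered here, and "the series" means these few. Any claim that something is new, unique, unknown or untested is made for them only; others in the source may bear on it.

Measured compounds:
Compound 1, `Cc1ccc(C(=O)Nc2sc3c(c2C(N)=O)CCN(Cc2c(Cl)cccc2Cl)C3)cc1` — 12300 nM
Compound 2, `Cc1ccc(C(=O)Nc2sc3c(c2C(N)=O)CCN(Cc2ccc(Cl)cc2Cl)C3)cc1` — 25500 nM
Compound 3, `Cc1ccccc1C(=O)Nc1sc2c(c1C(N)=O)CCN(C(=S)Nc1ccccc1Cl)C2` — 11000 nM

In a functional assay on MKN-74 cells (Homo sapiens) for antiproliferative activity, with a stated time of 24 h (on this read-out higher numbers stand for weaker inhibition and lower numbers for stronger inhibition), compound 3 gives the lowest of the three numbers, but its gap to compound 1 lies within the usual scatter of repeated measurements, so the two cannot be ranked against each other; only compound 2 stands clearly apart with its higher number.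

Compound 4, `Cc1ccc(C(=O)Nc2sc3c(c2C(N)=O)CCN(C(=S)Nc2ccccc2Cl)C3)cc1`, has the same atoms as compound 3 joined differently: 4-methylphenyl in place of 2-methylphenyl on a carbonyl carbon. The 4-methylphenyl that enters is the same group that compounds 1 and 2 carry on their carbonyl carbon.

Going by the values given here, the single measured step, a 2.1-fold higher number from compound 1 to compound 2 (0.32 log units; beyond the scatter), concerns a different part of the molecule and gives no guidance on moving the methyl group on the aromatic ring bound to the carbonyl carbon. Among the compounds with values here, with no measured step bearing on this change, no shift beyond the scatter is expected in this assay; the estimated step is no change at the digits printed from compound 3 to compound 4 (within the scatter). Compound 4 is therefore expected to give about 11000 nM, somewhere between 4000 nM and 30000 nM.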

Compound 4, half-maximal inhibitory concentration: 11300 nM
For compound 4 the middle estimate is 1.0-fold (0.01 log units) below the measured one; the measured number falls inside the stated range.
By their numbers in this assay, from the lowest: compounds 3, 4 and 1 (each within the scatter of the next); then compound 2.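

Moving the methyl group, with 4-methylphenyl in place of 2-methylphenyl on a carbonyl carbon, gives the first direct reading at this place: in this assay there is a 1.0-fold higher number from compound 3 to compound 4 (0.01 log units; within the scatter) and so no detectable change. Compound 4 also links this series to the benzyl-type compounds through the group on an amine nitrogen in a ring, with a 2.3-fold lower number from compound 2 to compound 4 (0.35 log units; beyond the scatter) but only a 1.1-fold lower number from compound 1 to compound 4 (0.04 log units; within the scatter) so that exchange matters against one dichlorophenyl partner and cannot be told apart against the other. No measurement here offers an explanation for these results.

From the compounds shown here alone, whether 3-methylphenyl, or an unsubstituted phenyl, would also leave the number unchanged remains open. So does whether a carboxylic acid or an amine on that ring, in place of the methyl group, would shift it beyond the scatter.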